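Methylsulfanyl Added to Two Cores That Stay Inactive

The source may hold more compounds than are shown below. What is called first, only, known or untested is meant among the compounds shown, and "the series" means these compounds.

Compound 1 `COC(=O)C1=C(C)N=C(SC)NC1c1cccc([N+](=O)[O-])c1`: a limit of > 30000 nM
Compound 2 `COC(=O)C1=C(C)N=C(SC)NC1c1cccc([N+](=O)[O-])c1SC`: a limit of > 30000 nM
Compound 3 `CSC1=NC(c2cccc([N+](=O)[O-])c2)C2=C(O)OCC2=N1`: a limit of > 30000 nM

In a functional assay (aorta) with Oryctolagus cuniculus as the target (a higher number here means that more compound is needed for the effect, a lower number that less compound is needed), compound 1 reaches only the limit of the assay, > 30000 nM, and no number is obtained. Compound 2 likewise returns only a limit in this assay, > 30000 nM. The change between them is methylsulfanyl in place of hydrogen on an aromatic carbon, and the step that the two limits leave unreadable from compound 1 to compound 2 cannot be sized, since both ends are limits.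

Compound 3 again gives only a limit in this assay, > 30000 nM. The difference between the core of compound 3 and the core of compound 1 is not broken down here.

Compound 4 `CSC1=NC(c2cc([N+](=O)[O-])ccc2SC)C2=C(O)OCC2=N1` is not yet measured. It differs from compound 3 by methylsulfanyl in place of hydrogen on an aromatic carbon. This is the same kind of change as that from compound 1 to compound 2, but not the same: in compound 2 the entering group is ortho to a nitro group, while in compound 4 it is para to a nitro group.

What can be expected rests on (the limit of > 30000 nM in this assay, at which 3 of the 3 values shown sit). For the measured compounds named here, because the step that the two limits leave unreadable from compound 1 to compound 2 is unreadable and both its ends sit at the limit, the same kind of change on the core of compound 3 is expected to leave compound 4 at the limit as well, and the step that the limit leaves unreadable from compound 3 to compound 4 is estimated to be no real step. Compound 4 is therefore expected to give about 60000 nM in this assay, somewhere between 20000 nM and 300000 nM, most likely reported only as a limit.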

Compound 4, half-maximal effective concentration: > 30000 nM
Compound 4: only a limit was reported; the forecaster's own chance of this, stated with the estimate: 85%; the middle value is on the limit's open side.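

In this assay compound 4 returns only a limit, > 30000 nM. Compound 3 also returns only a limit, so no step can be read between compound 3 and compound 4. The compounds shown leave open whether methylsulfanyl in place of hydrogen on an aromatic carbon changes the effect on either core, because none of them yields a number: the limit of > 30000 nM in this assay, at which 4 of the 4 values shown sit.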